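Extending a Methoxy to Isobutoxy on a Shared Core

The source may report more compounds than this note shows. Statements on the series, on what has been measured and on what is new or still open speak of the compounds shown alone.

Measured so far:
- Compound 1, `COc1cc(-c2nc3cc(/C=C4\SC(=O)NC4=O)ccc3[nH]2)cc(OC)c1OC`: in an ADME assay on HEK-293T cells (Homo sapiens) for inhibition, read by MTT assay, with a stated time of 48 h (on this read-out lower numbers stand for stronger inhibition and higher numbers for weaker inhibition), compound 1 gives 13600 nM.
- Compound 2, `COc1ccc(-c2nc3cc(/C=C4\SC(=O)NC4=O)ccc3[nH]2)cc1OC`: in this assay compound 2 gives 21700 nM.
- Compound 3, `COc1cc(OC)c(-c2nc3cc(/C=C4\SC(=O)NC4=O)ccc3[nH]2)cc1OC`: in this assay compound 3 gives 15300 nM.

All three share one core and differ only in how many methoxy groups sit on the pendant aromatic ring. Compound 2, with two methoxy groups, is the reference here. The steps around it are small: a 1.6-fold higher number from compound 1 to compound 2 (0.20 log units; within the scatter) and a 1.4-fold lower number from compound 2 to compound 3 (0.15 log units; within the scatter). Compound 2 thus sits within the scatter of both neighbours, and the three numbers cannot be ranked against each other.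

Compound 4, `COc1cc(-c2nc3cc(/C=C4\SC(=O)NC4=O)ccc3[nH]2)ccc1OCC(C)C`, is not yet measured. It differs from compound 2 by isopropyl in place of hydrogen on a saturated chain carbon bound to an oxygen on an aromatic ring, which, cut one bond further out, reads as methoxy becoming isobutoxy. Within the data shown here, no measured step touches this kind of chain extension; the two steps in hand concern adding or removing a methoxy on an aromatic carbon, and both stayed within the scatter. With nothing pointing to a large move, the expected step in this assay is a 1.2-fold lower number from compound 2 to compound 4 (0.08 log units; within the scatter), no larger than the scatter. Compound 4 is therefore estimated at 18000 nM, with a range from 6000 nM to 50000 nM.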

Compound 4, half-maximal inhibitory concentration: 14100 nM
For compound 4 the middle estimate is 1.3-fold (0.11 log units) above the measured one; measured number inside the range.
By their numbers in this assay, from the lowest: compounds 1, 4, 3 and 2 (each within the scatter of the next).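

Among these compounds, compound 4 is the first change here to the chain on the oxygen itself, whereas the earlier steps only added or removed a methoxy on an aromatic carbon. In this assay, going from methoxy to isobutoxy gives a 1.5-fold lower number from compound 2 to compound 4 (0.19 log units; within the scatter), so adding an isopropyl on this saturated chain carbon bound to an oxygen on an aromatic ring produces no readable difference. The position therefore tolerates this branched extension with no detectable effect on the number, although this single step cannot separate a small real shift from ordinary variation, and no available information offers an explanation for the result.

The compounds shown leave open whether a longer chain, such as hexyl, would stay within the scatter of compound 2 in the same way as the isobutoxy of compound 4. Among the compounds shown here, they also do not tell whether a chain ending in an amine or a carboxylic acid at this place would produce the first step that lies beyond the scatter.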